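The source may report more compounds than this note shows. Statements on the series, on what has been measured and on what is new or still open speak of the compounds shown alone.

Measured compounds:

compound 1, `CC1CCN(C2CCN(S(=O)(=O)c3cn(C)c(=O)n(C)c3=O)CC2)CC1`: > 5000 nM in a functional assay on DLD-1 cells (Homo sapiens) for antiproliferative activity, read by CellTiter-Glo, with a stated time of 72 h (a higher number here means a weaker inhibitor, a lower number a stronger inhibitor), which is a limit of the assay rather than a number.

compound 2, `CC1CCN(C2CCN(S(=O)(=O)c3ccc(C#N)cc3)CC2)CC1`: 2800 nM in this assay.

Compound 2 therefore holds the only number shown in this assay; the other entry, for compound 1, is a limit, (the limit of > 5000 nM in this assay, at which 1 of the 2 values shown sits). On the evidence in hand compound 2 is a weak inhibitor, and compound 1 cannot be placed relative to it beyond the fact that its value sits at the limit.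

Compound 3, `CCc1ccc(S(=O)(=O)N2CCC(N3CCC(C)CC3)CC2)cc1`, differs from compound 2 in one place: ethyl in place of cyano on an aromatic carbon. Among the compounds with values here, no measured pair shows this same exchange, so its effect in this assay is unknown. Compound 2 starts from a weak value of 2800 nM, and the exchange of cyano for ethyl on the aromatic carbon gives no measured basis for expecting a gain. The expected step from compound 2 to compound 3 in this assay is a 1.3-fold higher number from compound 2 to compound 3 (0.10 log units; within the scatter), a drift toward weaker inhibition that may not exceed the scatter. Compound 3 is therefore estimated at 3500 nM, with a range of 1200 nM to 10000 nM, and a fair chance that only a limit is reported.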

Compound 3, half-maximal inhibitory concentration: > 5000 nM
Compound 3 was reported as a limit; the forecaster's own chance of this, stated with the estimate: 30%; at least 1.4-fold (0.15 log units) between middle value and limit.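

In this assay, within the data shown here, putting ethyl in place of cyano on the aromatic carbon para to a large group gives an at least 1.7-fold higher number from compound 2 to compound 3 (0.25 log units; that floor lies within the scatter), the first reading of any change at this position. That figure is only a floor, and since the floor lies within the scatter, the result does not establish that the 4-ethylphenyl compound is truly weaker than the 4-cyanophenyl compound; it shows only that ethyl brings no measurable gain here. Compound 3 has joined compound 1 at the limit, so compound 2 remains the only compound with a number, and the limit now takes in most of the compounds shown: the limit of > 5000 nM in this assay, at which 2 of the 3 values shown sit.

The compounds shown leave open how far the true value of compound 3 lies from that of compound 2, and whether cyano itself contributes anything to the activity of compound 2. They also leave open how this position would respond to other groups, such as an amine, a carboxylic acid or a longer alkyl chain in place of ethyl, and whether any of these would bring a value well clear of the limit.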